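This account rests on a few compounds, and the source may have more. Where it says the series, first, only, none or still open, it means among the compounds named here.

Measured so far:
- compound 1, `CSc1nc(-c2ccc(S(N)(=O)=O)cc2)n(-c2ccc(Cl)cc2)n1`, in a functional assay on Caco-2 cells (Homo sapiens) for antiproliferative activity, read by MTT assay, with a stated time of 72 h (a lower number here means a stronger inhibitor, a higher number a weaker inhibitor), compound 1 gives 41300 nM
- compound 2, `COc1cc(/C=C/C(=O)OCCSc2nc(-c3ccc(S(C)(=O)=O)cc3)n(-c3ccc(Br)cc3)n2)ccc1OC(C)=O`, in this assay compound 2 gives 12100 nM

Of these two, compound 2 has the lower number, and the gap to compound 1 lies beyond the usual scatter of this assay. Compound 3, `COc1cc(/C=C/C(=O)OCCSc2nc(-c3ccc(S(C)(=O)=O)cc3)n(-c3ccc(C(F)(F)F)cc3)n2)ccc1OC(C)=O`, has not yet been measured in this assay. It differs from compound 2 in one place: trifluoromethyl in place of bromo on an aromatic carbon. Going by the values given here, no pair of measured compounds differs by this change alone, so nothing here shows its size or direction. The step from compound 2 to compound 3 is therefore expected to be small, a 1.0-fold lower number from compound 2 to compound 3 (0.00 log units; within the scatter), not beyond the scatter. Compound 3 is estimated at 12000 nM, within 4000 nM to 36000 nM.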

Compound 3, half-maximal inhibitory concentration: 10800 nM
Compound 3: middle estimate off by 1.1-fold (0.05 log units), on the high side; the range from low to high includes it.
By their numbers in this assay, from the lowest: compounds 3 and 2 (each within the scatter of the next); then compound 1.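

On this aromatic carbon, para to a large group, the swap gives a 1.1-fold lower number from compound 2 to compound 3 (0.05 log units; within the scatter) in this assay. This position therefore accepts trifluoromethyl, with four heavy atoms, in place of bromo, with one, without a change that can be told from scatter. Nothing shown explains why the two groups read alike.

Neither group has a hydrogen-bond donor or acceptor or a net charge. From the compounds shown here alone, how this position would respond to an amine or a carboxylic acid remains open.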